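The source may report more compounds than this note shows. Statements on the series, on what has been measured and on what is new or still open speak of the compounds shown alone.

Measured so far in a functional assay on CCRF-CEM cells (Homo sapiens) for inhibition, read by cell counting, with a stated time of 72 h; a lower number here means a stronger inhibitor, a higher number a weaker inhibitor:

compound 1, `CCN(CC)CN1C(=O)/C(=N/NC(=S)Nc2ccc(Cl)cc2)c2ccccc21`, 10000 nM
compound 2, `CCN(CC)CN1C(=O)/C(=N/NC(=S)Nc2ccc(OC)cc2)c2ccccc21`, 1900 nM

Compound 2 gives the lowest of the two numbers; the only other point, compound 1, sits higher, and the step from chloro to methoxy on the aromatic carbon, a 5.3-fold lower number from compound 1 to compound 2 (0.72 log units; beyond the scatter), lies beyond the scatter. Compound 3, `CCN(CC)CN1C(=O)/C(=N/NC(=S)Nc2ccccc2)c2ccccc21`, is not yet measured. Against compound 2 the difference is hydrogen in place of methoxy on an aromatic carbon; cut one bond further out it reads 4-methoxyphenyl to phenyl. Within the data shown here, no measured pair removes the group at this place entirely, so the step of a 5.3-fold lower number from compound 1 to compound 2 (0.72 log units; beyond the scatter) is the only one bearing on it, and it shows only that changing the group on this aromatic carbon moves the number by a modest amount. Among the measured compounds shown here, with no direct precedent, the expectation for compound 3 is a number between those of compound 1 and compound 2, a modest move upward from compound 2, estimated as a 2.1-fold higher number from compound 2 to compound 3 (0.32 log units; beyond the scatter). The estimate for compound 3 in this assay is therefore 4000 nM, with a range from 1500 nM to 12000 nM.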

Compound 3, half-maximal inhibitory concentration: 11000 nM
Estimate against measurement, compound 3: 2.8-fold (0.44 log units) below; the range from low to high includes it.
By their numbers in this assay, from the lowest: compound 2; then compounds 1 and 3 (each within the scatter of the next).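

In this assay, compound 3 gives this position its first reference point with nothing on the aromatic carbon, and the step of a 5.8-fold higher number from compound 2 to compound 3 (0.76 log units; beyond the scatter) shows that the methoxy of compound 2 counts for something against plain hydrogen, which the chloro-to-methoxy comparison alone could not show. The other new step, a 1.1-fold higher number from compound 1 to compound 3 (0.04 log units; within the scatter), lies within the scatter, so chloro and hydrogen at this place cannot be told apart, and among these three compounds only the 4-methoxyphenyl compound stands apart, with no trend running across all the groups tested. Nothing at hand accounts for why methoxy differs from the other two groups here.

Going by these compounds, whether the lower number is particular to methoxy remains open, since ethoxy, hydroxy or a dimethylamino group on this same aromatic carbon could separate a single-group effect from a wider one. On these data alone, all three compounds share everything outside this substituent, so it also remains open whether the methoxy step holds on a changed core, or whether methoxy elsewhere on the ring gives the same result.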